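The compounds below may be only part of what the source reports. "The series", "measured", "known", "first", "only" and "open" are said of these compounds alone.

Measured so far in a functional assay on CHO-K1 cells with Glucose-dependent insulinotropic receptor (Homo sapiens) as the target, read by a luciferase reporter, with a stated time of 5 h; a lower number here means a smaller maximal response, a higher number a larger maximal response:
- compound 1 `CCCOC(=O)N1CCC(Oc2ncnc3c2CCN3c2ccc(S(C)(=O)=O)cc2F)CC1` gives 111%
- compound 2 `CS(=O)(=O)c1ccc(N2CCc3c(OC4CCN(C(=O)OCCF)CC4)ncnc32)c(F)c1` gives 86%
- compound 3 `CSC(=O)N1CCC(Oc2ncnc3c2CCN3c2ccc(S(C)(=O)=O)cc2F)CC1` gives 135%

Compound 3 stands highest of the three numbers: a number 24 percentage points higher from compound 1 to compound 3 (beyond the scatter) and a number 49 percentage points higher from compound 2 to compound 3 (beyond the scatter), both beyond the scatter. Compound 4 `CC(C)S(=O)(=O)N1CCC(Oc2ncnc3c2CCN3c2ccc(S(C)(=O)=O)cc2F)CC1` differs from compound 3 by isopropylsulfonyl in place of (methylsulfanyl)carbonyl on an amine nitrogen in a ring. Among the measured compounds shown here, no measured step removes the carbonyl or brings in a sulfonyl; the known steps only vary what sits on the carbonyl carbon (a number 24 percentage points higher from compound 1 to compound 3 (beyond the scatter), a number 49 percentage points higher from compound 2 to compound 3 (beyond the scatter)) or further along the chain (a number 25 percentage points lower from compound 1 to compound 2 (beyond the scatter)), and those already moved the number by modest to large amounts. A step of at least modest size is therefore expected, more likely downward toward the values of compounds 1 and 2 than upward, as a number 30 percentage points lower from compound 3 to compound 4 (beyond the scatter). The estimate for compound 4 is 105% in this assay, within 70% to 140%.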

Compound 4, largest response reached (reported as percent of maximum), in percent of the reference or control that the assay uses: 62%
Compound 4: the middle estimate sits 43 percentage points above what was measured, outside the stated range (below it).
By their numbers in this assay, from the lowest: compound 4; then compound 2; then compound 1; then compound 3.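

On the amine nitrogen in a ring, isopropylsulfonyl gives the lowest number of the series in this assay, below all three carbonyl-linked groups (a number 73 percentage points lower from compound 3 to compound 4 (beyond the scatter); a number 49 percentage points lower from compound 1 to compound 4 (beyond the scatter); a number 24 percentage points lower from compound 2 to compound 4 (beyond the scatter)). The maximal response at this position therefore also shifts with a change of the group as a whole, not only with what sits on the carbonyl carbon. Nothing available explains the drop.

Open, as far as these compounds go, is whether the low number belongs to sulfonyl groups generally or to isopropylsulfonyl alone, which a methylsulfonyl or a phenylsulfonyl group would test. A urea or an acetyl group on this nitrogen also remains to be placed against these values.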